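Replacing the acyl group of a trimethoxyphenyl amide

A few compounds are considered here, and "the series" means these few. Any claim that something is new, unique, unknown or untested is made for them only; others in the source may bear on it.

Measured compounds:
compound 1 `COc1ccc(CN(C(=O)C=C(C)C)c2cc(OC)c(OC)c(OC)c2)cc1O` — 290 nM
compound 2 `C/C=C/C(=O)N(Cc1ccc(OC)c(OC)c1)c1cc(OC)c(OC)c(OC)c1` — 32800 nM

For the measured compounds named here, in a functional assay on HCT-116 cells (Homo sapiens) for inhibition, read by MTT assay, with a stated time of 48 h (a lower number here means a stronger inhibitor, a higher number a weaker inhibitor), compound 1 gives 290 nM, the lowest of the two numbers known. Going by the values given here, compound 2 gives 32800 nM in this assay, a far higher number, and the two compounds differ in more than one place, so the pair shows only that compound 1 stands well ahead.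

Compound 3 `COc1ccc(CN(C(=O)C[Se]C#N)c2cc(OC)c(OC)c(OC)c2)cc1O` has not yet been measured in this assay. It differs from compound 1 in one place: a group of 4 heavy atoms (2 carbon, 1 nitrogen, 1 selenium; no ring) in place of a group of 4 heavy atoms (4 carbon; no ring), on a carbonyl carbon. The amide-type nitrogen, the core of compound 1 and the remainder of the molecule are kept unchanged.

Among the compounds with values here, no single-point step between measured compounds is available to guide this change, and the group that enters has no counterpart among the measured compounds. The account therefore rests on compound 1 alone. A step of moderate size is expected from compound 1 to compound 3 in this assay, a 2.1-fold higher number from compound 1 to compound 3 (0.32 log units; beyond the scatter), most likely toward a higher number, though a number within the scatter of compound 1 cannot be excluded. Compound 3 is estimated to give 600 nM in this assay, within a range from 90 nM to 4000 nM.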

Compound 3, half-maximal inhibitory concentration: 310 nM
The estimate for compound 3 lay 1.9-fold (0.29 log units) above the measured number; the range from low to high includes it.
By their numbers in this assay, from the lowest: compounds 1 and 3 (each within the scatter of the next); then compound 2.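

In this assay, putting the selenium-containing group with its triple bond in place of the 2-methylprop-1-en-1-yl group on the carbonyl carbon gives a 1.1-fold higher number from compound 1 to compound 3 (0.03 log units; within the scatter), so the two compounds cannot be told apart here. This place therefore accepts a group of quite different atoms, and on the core of compound 1 an all-carbon group with a double bond is not required for a number of this order. Nothing measured here bears on why the two numbers agree.

The compounds shown leave open whether the number would hold with sulfur in place of the selenium, with a plain cyanomethyl group, or with an amine or a longer chain on the carbonyl carbon. They also leave open whether the agreement between compound 1 and compound 3 would carry over to the rest of compound 2, which differs from each of them in more than one place.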